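Nitrate-bearing cinnamate esters with no measurable cytotoxicity

The source may report more compounds than this note shows. Statements on the series, on what has been measured and on what is new or still open speak of the compounds shown alone.

Three esters were tested in a functional assay on cells (Homo sapiens) for cytotoxicity, read by resazurin assay, with a stated time of 72 h; on this read-out higher numbers stand for weaker inhibition and lower numbers for stronger inhibition. Compound 1 `O=C(/C=C/c1ccc(OCCCCCO[N+](=O)[O-])c(O)c1)OCCCCCO[N+](=O)[O-]` carries a hydroxy on its ring; in this assay compound 1 gives only a limit, > 50000 nM. Compound 2 `COc1cc(/C=C/C(=O)OCCCO[N+](=O)[O-])ccc1OCCCO[N+](=O)[O-]` is also known only by a limit in this assay, > 50000 nM. Compound 3 `COc1cc(/C=C/C(=O)OCCCCCO[N+](=O)[O-])ccc1OCCCCCO[N+](=O)[O-]` likewise reaches only a limit in this assay, > 50000 nM. The difference between the cores of compound 2 and compound 3 is not broken down here. From compound 3 to compound 1 the change is hydrogen in place of methyl on an oxygen on an aromatic ring, and the step that the two limits leave unreadable from compound 3 to compound 1 stays unreadable because the limit of > 50000 nM in this assay, at which 3 of the 3 values shown sit, holds all three values. Compound 4 `O=C(/C=C/c1ccc(OCCCO[N+](=O)[O-])c(O)c1)OCCCO[N+](=O)[O-]` arises from compound 2 by the same change, (hydrogen in place of methyl on an oxygen on an aromatic ring). The step that the limit leaves unreadable from compound 2 to compound 4 is therefore expected to be flat, resting on compound 3 and compound 1 whose values both sit at the limit. For compound 4 the estimate is 100000 nM.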

Compound 4, half-maximal inhibitory concentration: 4980 nM
Compound 4: middle estimate off by 20-fold (1.30 log units), on the high side; measured number below the stated range.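

In this assay, the change from methoxy to hydroxy gives an at least 10-fold lower number from compound 2 to compound 4 (1.00 log units; beyond the scatter), so on the core of compound 2 this change goes with stronger inhibition. On the other core it shows no such reading, since compound 1 gives > 50000 nM, which is a limit. The change therefore does not carry with a readable size from one core to the other, and the true size of the step on the core of compound 2 stays unknown, with the values of this small set mostly confined to a limit: the limit of > 50000 nM in this assay, at which 3 of the 4 values shown sit.

The compounds shown leave open how an amine or a carboxylic acid in place of the hydroxy would read in this assay. They also leave open how a longer chain would read on the core of compound 4.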